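Low unbound fractions among the carbamate-bearing acids

The compounds below may be only part of what the source reports. "The series", "measured", "known", "first", "only" and "open" are said of these compounds alone.

Compound 1 `Cc1noc(-c2ccc(O[C@H]3CCC[C@H](C(=O)O)C3)cc2)c1COC(=O)N(C)CCC(C)C`: 0.002
Compound 2 `Cc1noc(-c2ccc(O[C@H]3CCC[C@H](C(=O)O)C3)cc2)c1CNC(=O)OCCC(C)(C)C`: 0.001
Compound 3 `Cc1noc(-c2ccc(O[C@H]3CCC[C@H](C(=O)O)C3)cn2)c1COC(=O)N(C)C1CCCC1`: 0.009

In an ADME assay on the whole organism (plasma, Rattus norvegicus, strain Sprague-Dawley) for protein binding, read by LC-MS, with a stated time of 24 h (a higher number here means a larger unbound share of the compound, a lower number a smaller unbound share), compound 2 gives 0.001. Compound 1, at 0.002, lies within the scatter of it, and the two together form the low end of the three numbers. Compound 3, at 0.009, lies beyond the scatter of compound 2, on the high side.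

The next structure is compound 4 `Cc1noc(-c2ccc(O[C@H]3CCC[C@H](C(=O)O)C3)cc2)c1COC(=O)N(C)C1CCCC1`, and the change leading to it is a group of 10 heavy atoms (7 carbon, 1 nitrogen, 2 oxygen; one five-membered non-aromatic ring of carbon only) in place of a group of 10 heavy atoms (7 carbon, 1 nitrogen, 2 oxygen; no ring), on a saturated chain carbon bound to an aromatic carbon. One measured step falls at this place: a 2.0-fold lower number from compound 1 to compound 2 (0.30 log units; within the scatter). That step exchanged one group without a ring for another of equal heavy-atom count. Going by the values given here, no measured step introduces the five-membered ring on the core of compound 2. Compound 3 carries the entering group on a different core, so its 0.009 serves only as a loose guide to the high side.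

On the evidence of the step to compound 2, no change beyond the scatter is expected in this assay, with a slight lean towards a higher number. The expected change is a 2.0-fold higher number from compound 2 to compound 4 (0.30 log units; within the scatter). The estimated unbound fraction for compound 4 is 0.002, with an expected range of 0.001 to 0.005.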

Compound 4, unbound fraction: 0.002
The estimate for compound 4 equals the measured number at the digits printed; the range from low to high includes it.
By their numbers in this assay, from the lowest: compounds 2, 1 and 4 (each within the scatter of the next); then compound 3.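

In this assay, cyclopentyl in place of isopentyl on an amide-type nitrogen gives no change at the digits printed from compound 1 to compound 4 (within the scatter), which shows that a five-membered carbon ring can enter at this position on the shared core without moving the number beyond the scatter. The exchange of the group with one hydrogen-bond donor for the ring-bearing group with none gives a 2.0-fold higher number from compound 2 to compound 4 (0.30 log units; within the scatter), so compounds 1, 2 and 4 stay together at the low end despite these differences in the group on the saturated chain carbon bound to an aromatic carbon. Nothing measured in this set bears on what lies behind these numbers.

On these data alone, compound 3 gives 0.009 and compound 4 gives 0.002 with the same cyclopentyl group on different cores, and it remains open whether this gap would recur with isopentyl or another group on the amide-type nitrogen. Also open, as far as these compounds go, is how this assay would read for an amine at the saturated chain carbon, or for a longer chain on the amide-type nitrogen.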